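A few compounds are considered here, and "the series" means these few. Any claim that something is new, unique, unknown or untested is made for them only; others in the source may bear on it.

Measured compounds: compound 1 `CC(C)=CCc1cc(C(=O)Nc2cc3ccc(OCCCN4CCCCC4)c(C)c3oc2=O)ccc1O`, compound 2 `CC(C)=CCc1cc(C(=O)Nc2cc3ccc(OCCCNCC(C)C)c(C)c3oc2=O)ccc1O`, compound 3 `CC(C)=CCc1cc(C(=O)Nc2cc3ccc(OCCCN(C(C)C)C(C)C)c(C)c3oc2=O)ccc1O`.

In a functional assay on MCF7 cells (Homo sapiens) for antiproliferative activity (a higher number here means a weaker inhibitor, a lower number a stronger inhibitor), compound 1 is reported only as a limit, > 50000 nM, and so it sits at the limit of > 50000 nM in this assay, at which 1 of the 3 values shown sits. Compound 2 gives 1320 nM in this assay. Compound 3 gives 1310 nM. The unmeasured compound 4 `CC(C)=CCc1cc(C(=O)Nc2cc3ccc(OCCCN(C)Cc4ccccc4)c(C)c3oc2=O)ccc1O` differs from compound 1 by benzyl(methyl)amino in place of piperidin-1-yl on a saturated chain carbon, three bonds along the chain from an oxygen on an aromatic ring. Among the compounds with values here, two measured steps bear on this change, an at least 37-fold lower number from compound 1 to compound 2 (1.57 log units; beyond the scatter) and an at least 38-fold lower number from compound 1 to compound 3 (1.58 log units; beyond the scatter), while between the two open-chain amines there is a 1.0-fold lower number from compound 2 to compound 3 (0.00 log units; within the scatter). Because of an at least 37-fold lower number from compound 1 to compound 2 (1.57 log units; beyond the scatter) and an at least 38-fold lower number from compound 1 to compound 3 (1.58 log units; beyond the scatter), a similarly large downward step in this assay is expected for compound 4. Compound 4 is therefore estimated at 1500 nM, with a range from 400 nM to 10000 nM, which would mean an expected at least 33-fold lower number from compound 1 to compound 4 (1.52 log units; beyond the scatter).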

Compound 4, half-maximal inhibitory concentration: 11500 nM
Beside the measured number, compound 4's estimate is 7.7-fold (0.88 log units) below it, outside the stated range (above it).
By their numbers in this assay, from the lowest: compounds 3 and 2 (each within the scatter of the next); then compound 4. At a limit, above all of these: compound 1.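

At this position, an open-chain amine in place of piperidin-1-yl does not by itself reach the level of the earlier open-chain amines in this assay: benzyl(methyl)amino brings an 8.7-fold higher number from compound 2 to compound 4 (0.94 log units; beyond the scatter) and an 8.8-fold higher number from compound 3 to compound 4 (0.94 log units; beyond the scatter), so the choice among such amines matters here. An improvement on piperidin-1-yl remains, with an at least 4.3-fold lower number from compound 1 to compound 4 (0.63 log units; beyond the scatter). That step is only a bound, since compound 1 is reported as a limit: the limit of > 50000 nM in this assay, at which 1 of the 4 values shown sits.

Going by these compounds, it remains open whether the benzyl or the methyl group accounts for the rise. On these data alone, how a morpholin-4-yl or pyrrolidin-1-yl group would behave at this position also stays open.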